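The compounds below may be only part of what the source reports. "The series", "measured", "known", "first", "only" and "open" are said of these compounds alone.

Compound 1 `COc1cccc(-n2cc3nc(-c4cccnc4C)n(C[C@H]4CCCN(CC5CCCCC5)C4)c(=O)c3n2)c1` gives 200 nM in an assay on HEK293 cells for displacement of a labelled ligand from growth hormone secretagogue receptor type 1 (Homo sapiens), with a stated time of 60 min; a lower number here means a stronger inhibitor, a higher number a weaker inhibitor.
Compound 2 `CCO[C@@H](C)CN1CCC[C@H](Cn2c(-c3cccnc3C)nc3cn(-c4cccc(OC)c4)nc3c2=O)C1` gives 5 nM in this assay.
Compound 3 `COc1cccc(-n2cc3nc(-c4cccnc4C)n(C[C@H]4CCCN(CC(C)C)C4)c(=O)c3n2)c1` gives 5.7 nM in this assay.

Compound 3 sits close to compound 2: the gap between them, a 1.1-fold higher number from compound 2 to compound 3 (0.06 log units; within the scatter), is within the scatter, so the two cannot be told apart. Both stand far from compound 1, which is the weakest binder of the three, with a 35-fold lower number from compound 1 to compound 3 (1.55 log units; beyond the scatter) and a 40-fold lower number from compound 1 to compound 2 (1.60 log units; beyond the scatter).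

Compound 4 `COc1cccc(-n2cc3nc(-c4cccnc4C)n(C[C@H]4CCCN(CC5CCCCO5)C4)c(=O)c3n2)c1` differs from compound 3 in one place: oxan-2-yl in place of isopropyl on a saturated chain carbon bound to an amine nitrogen in a ring. The three measured steps all change the same group on the same chain carbon. A cyclohexyl ring there (compound 1) costs a great deal relative to both the isopropyl of compound 3 and the open-chain ether of compound 2. The group entering in compound 4 is a ring, as in compound 1, but it is a non-aromatic ring carrying an oxygen, which compound 2 shows to be tolerated in an open chain. The two precedents pull in opposite directions, so a middle outcome is the most reasonable guess, with a wide range. Compound 4 is therefore expected to bind more weakly than compound 3, by a 6.1-fold higher number from compound 3 to compound 4 (0.79 log units; beyond the scatter), and the estimate for compound 4 in this assay is 35 nM, between 8 nM and 180 nM.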

Compound 4, half-maximal inhibitory concentration: 120 nM
Estimate against measurement, compound 4: 3.4-fold (0.54 log units) below, and the stated range covers the measured number.
By their numbers in this assay, from the lowest: compounds 2 and 3 (each within the scatter of the next); then compounds 4 and 1 (each within the scatter of the next).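

Replacing the open-chain isopropyl on this saturated chain carbon with the oxan-2-yl ring brings a large loss of binding in this assay (a 21-fold higher number from compound 3 to compound 4 (1.32 log units; beyond the scatter)), and replacing the open-chain 1-ethoxyethyl with the same ring also does (a 24-fold higher number from compound 2 to compound 4 (1.38 log units; beyond the scatter)). The oxygen in the ring gives no visible gain over the all-carbon cyclohexyl ring, since the two compounds cannot be told apart (a 1.7-fold lower number from compound 1 to compound 4 (0.22 log units; within the scatter)). Across these four compounds, then, the numbers fall into two groups, with the two open-chain groups giving the low numbers and the two six-membered rings the high numbers; no compound goes against this, and an oxygen appears on both sides of the split, so its presence alone does not decide the outcome.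

Both rings shown are six-membered, so it remains open whether a smaller ring such as cyclopropyl would carry the same cost, and how a longer open chain such as n-pentyl or an amine such as dimethylamino would behave at this position. Nothing measured here tells why the two rings give such high numbers.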